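The compounds below may be only part of what the source reports. "The series", "measured", "known", "first", "only" and "open" are said of these compounds alone.

Of the compounds shown here, three have so far been measured in a functional assay on cells (T-cell, Homo sapiens) for inhibition; on this read-out higher numbers stand for weaker inhibition and lower numbers for stronger inhibition. Compound 1 `CC(C)Oc1nc(N)nc2ncc(-c3ccc(C#N)cc3)nc12` pairs an isopropoxy group with a cyanophenyl on the shared core; in this assay compound 1 reaches only the limit > 10000 nM, which is the edge of what the assay reports and not a number. Compound 3 `CCOc1nc(N)nc2ncc(-c3ccc(Cl)c(Cl)c3)nc12` likewise returns only the limit > 10000 nM in this assay. Within the data shown here, compound 2 `COc1ccc(-c2cnc3nc(N)nc(N4CCN(C(=O)c5ccccc5)CC4)c3n2)cc1OC` is different: in this assay compound 2 gives 400 nM, the one genuine number in the set. Compound 2 therefore stands alone with a measurable result, while the other two sit at the limit of > 10000 nM in this assay, at which 2 of the 3 values shown sit.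

Compound 4 `COc1ccc(-c2cnc3nc(N)nc(N4CCN(C(=O)Nc5ccc(C#N)cc5)CC4)c3n2)cc1OC` differs from compound 2 in a single place: (4-cyanophenyl)amino in place of phenyl on a carbonyl carbon. Cut one bond further out, the change reads benzoyl to (4-cyanophenyl)carbamoyl. Among the measured compounds shown here, no measured pair shows a step of this kind, so nothing in the data sets its size. The expected step is a 1.3-fold lower number from compound 2 to compound 4 (0.12 log units; within the scatter), a shift that stays inside the usual scatter of repeated measurements. Compound 4 is thus estimated to give about 300 nM in this assay, with a likely range from 80 nM to 1200 nM.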

Compound 4, half-maximal inhibitory concentration: 74 nM
Estimate against measurement, compound 4: 4.1-fold (0.61 log units) above; measured number below the stated range.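

In this assay, putting (4-cyanophenyl)amino in place of phenyl on the carbonyl carbon gives a 5.4-fold lower number from compound 2 to compound 4 (0.73 log units; beyond the scatter) and so shows that the group at this place can shift the read-out by more than repeat measurements normally would. The earlier compounds shown here could not show this: with a single real number among them, no step could be read, and this first step points toward stronger inhibition. The change brings in several features at once, among them a nitrogen carrying the amide hydrogen and a nitrile on the aromatic ring, and nothing measured here says which of them matters or why the step has this size.

The compounds shown leave open whether plain phenylamino, which has the nitrogen but no nitrile, or 4-cyanophenyl, which has the nitrile but no nitrogen, would account for the step. Also open, going by these compounds, is how far this place tolerates something quite different on the carbonyl carbon, such as a small methyl group or a saturated ring like cyclohexyl, and whether the number would keep falling or rise again.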